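The source may report more compounds than this note shows. Statements on the series, on what has been measured and on what is new or still open speak of the compounds shown alone.

Compound 3, `Cc1nc(-c2cccc(Cl)c2)sc1COc1ccc2c(c1)OCC2CC(=O)O`, is one of three compounds tested in a functional assay on CHO cells for agonist activity at Free fatty acid receptor 1 (Homo sapiens), read by FLIPR and calcium flux, tested at 100 nM; a lower number here means a weaker effect, a higher number a stronger effect of the compound at the concentration tested. Compound 3 gives 43%, which places it second highest of the three. The nearest neighbour is compound 2, `Cc1ccc(-c2nc(C)c(COc3ccc4c(c3)OCC4CC(=O)O)s2)cc1`, which gives 54.9%; the furthest is compound 1, `O=C(O)CC1COc2cc(OCc3cc(-c4ccccc4)on3)ccc21`, which gives 0.84% on a different core.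

Compound 4, `COc1cc(OC)cc(-c2nc(C)c(COc3ccc4c(c3)OCC4CC(=O)O)s2)c1`, differs from compound 3 in one place: 3,5-dimethoxyphenyl in place of 3-chlorophenyl on an aromatic carbon.

Within the data shown here, only one measured step bears on this change, and it concerns the same aryl position: a number 11.9 percentage points lower from compound 2 to compound 3 (beyond the scatter). It shows that exchanging the aryl group on this position moves this assay by a modest amount beyond the scatter, but it offers no direct guide for the dimethoxy pattern. Compound 3 with its aryl change already sat below compound 2, so a further aryl exchange is expected to shift this assay modestly in either direction, most likely staying near the present value.

For compound 4 the estimate is 40%, between 15% and 65%, which is expected to mean a step of a number 3 percentage points lower from compound 3 to compound 4 (within the scatter).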

Compound 4, a percentage reported as activity, at one concentration (the size of the read-out at that concentration, not a potency): 17.5%
Compound 4: the middle estimate sits 22.5 percentage points above what was measured; the measured number falls inside the stated range.
By their numbers in this assay, from the lowest: compound 1; then compound 4; then compound 3; then compound 2.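

At this aryl position on the five-membered ring, the exchange is not a small adjustment in this assay: a number 25.5 percentage points lower from compound 3 to compound 4 (beyond the scatter), so the position distinguishes 3,5-dimethoxyphenyl from 3-chlorophenyl as well as from 4-methylphenyl. Measured against the highest of the compounds sharing this core, the change is a large one, a number 37.4 percentage points lower from compound 2 to compound 4 (beyond the scatter), and the three aryl groups now spread well beyond the scatter, with 3,5-dimethoxyphenyl, which carries 2 hydrogen-bond acceptors, lowest of them. Nothing available accounts for why this group lowers the read-out.

The compounds shown leave open whether the drop goes with both methoxy groups together or would already appear with a phenyl ring bearing a single methoxy group. They also do not show how an unsubstituted phenyl ring or a pyridine ring would read at this position.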